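This account rests on a few compounds, and the source may have more. Where it says the series, first, only, none or still open, it means among the compounds named here.

Values in a functional assay on MKN-74 cells (Homo sapiens) for antiproliferative activity, with a stated time of 24 h (on this read-out lower numbers stand for stronger inhibition and higher numbers for weaker inhibition), for the three measured compounds:

compound 1, `NC(=O)c1c(NC(=O)c2ccccc2Cl)sc2c1CCN(C(=S)Nc1ccc(C(F)(F)F)cc1)C2`: 7090 nM
compound 2, `COc1ccc(NC(=S)N2CCc3c(sc(NC(=O)c4ccccc4Cl)c3C(N)=O)C2)cc1`: 19600 nM
compound 3, `COc1ccccc1NC(=S)N1CCc2c(sc(NC(=O)c3ccccc3C(F)(F)F)c2C(N)=O)C1`: 34500 nM

Compound 1 and compound 2 differ in one place only: methoxy in place of trifluoromethyl on an aromatic carbon. On this assay the step is a 2.8-fold higher number from compound 1 to compound 2 (0.44 log units; beyond the scatter). Compound 3 carries a different core from compound 1; the difference between the two cores is not broken down here. Against compound 2, compound 3 gives a number that is within the scatter, so no order between the two is drawn.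

Compound 4, `COc1ccccc1NC(=S)N1CCc2c(sc(NC(=O)c3ccccc3OC)c2C(N)=O)C1`, has not been measured. It differs from compound 3 in one place: methoxy in place of trifluoromethyl on an aromatic carbon. Going by the values given here, this is the same kind of change as the one from compound 1 to compound 2, but not the same: there the methoxy enters para to a large group, on the ring of the (4-(trifluoromethyl)phenyl)amino part, whereas here it enters ortho to a large group, on the ring of the (2-(trifluoromethyl)phenyl)carbonyl part. Among the compounds with values here, only one measured pair carries this kind of change, so the expectation rests on a single step.

Within the data shown here, for compound 4 the step is expected to be a 1.6-fold higher number from compound 3 to compound 4 (0.20 log units; within the scatter), a modest rise in the number because the only measured example of this kind of change gave a 2.8-fold higher number from compound 1 to compound 2 (0.44 log units; beyond the scatter), while the different place around the change argues for a wide range. The estimate for compound 4 on this assay is 55000 nM, expected to lie between 15000 nM and 160000 nM.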

Compound 4, half-maximal inhibitory concentration: > 50000 nM
Compound 4: a limit, no number; the forecaster's own chance of this, stated with the estimate: 25%; the middle value lies beyond the limit too.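

In this assay compound 4 gives > 50000 nM, which is a limit of the assay and not a number. The step for methoxy in place of trifluoromethyl can therefore be read only as a floor, an at least 1.4-fold higher number from compound 3 to compound 4 (0.16 log units; that floor lies within the scatter), so on this core a change beyond the scatter is neither shown nor ruled out. Carried from one core to the other, the change gives no reversal in direction, but its size on the second core stays unfixed and the two steps cannot be called alike or different: the same change on two cores in this assay, a 2.8-fold higher number (0.44 log units; beyond the scatter) from compound 1 to compound 2 and an at least 1.4-fold higher number (0.16 log units; that floor lies within the scatter) from compound 3 to compound 4; the limit leaves it open whether they differ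

The compounds shown leave open how the number responds to other groups in place of trifluoromethyl on the (2-(trifluoromethyl)phenyl)carbonyl part, for instance a nitrile, an amine or a carboxylic acid. Going by these compounds alone, with only one step for this change that carries a full number, they also leave open whether the (4-(trifluoromethyl)phenyl)amino part and the (2-(trifluoromethyl)phenyl)carbonyl part respond to the same change to a similar extent.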